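Aryl exchange from compound 2 to compound 3

The compounds below may be only part of what the source reports. "The series", "measured", "known", "first", "only" and "open" are said of these compounds alone.

Among the measured compounds shown here, in a functional assay on A549 cells (Homo sapiens) for cytotoxicity, read by MTT assay, with a stated time of 72 h (on this read-out lower numbers stand for stronger inhibition and higher numbers for weaker inhibition), compound 1 `O=C(/C=C/c1cc(Br)c(O)c(Br)c1)Nc1cc2c(Nc3ccc(F)c(Cl)c3)ncnc2cc1O[C@H]1CCOC1` gives 28800 nM and compound 2 `COc1cc(/C=C/C(=O)Nc2cc3c(Nc4ccc(F)c(Cl)c4)ncnc3cc2O[C@H]2CCOC2)cc(OC)c1` gives 10800 nM, the lower of the two numbers so far. Next comes compound 3 `COc1ccc(/C=C/C(=O)Nc2cc3c(Nc4ccc(F)c(Cl)c4)ncnc3cc2O[C@H]2CCOC2)cc1`, with 4-methoxyphenyl in place of 3,5-dimethoxyphenyl on a double-bonded chain carbon bound to a double-bonded chain carbon. One measured step changes this same place, a 2.7-fold lower number from compound 1 to compound 2 (0.43 log units; beyond the scatter), and it is modest. That single step sets no firm direction, so no step beyond the scatter is expected in this assay. The estimated step is a 1.1-fold higher number from compound 2 to compound 3 (0.05 log units; within the scatter). Compound 3 is expected at 12000 nM, with a range of 5000 nM to 28000 nM.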

Compound 3, half-maximal inhibitory concentration: 3050 nM
Compound 3: middle estimate off by 3.9-fold (0.59 log units), on the high side; the whole stated range lies above it.
By their numbers in this assay, from the lowest: compound 3; then compound 2; then compound 1.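

In this assay, the aryl group on a double-bonded chain carbon bound to a double-bonded chain carbon has more influence than the first step showed: 4-methoxyphenyl in place of 3,5-dimethoxyphenyl gives a 3.5-fold lower number from compound 2 to compound 3 (0.55 log units; beyond the scatter), and in place of 3,5-dibromo-4-hydroxyphenyl gives a 9.4-fold lower number from compound 1 to compound 3 (0.98 log units; beyond the scatter). Among these three compounds, the smaller aryl group with one methoxy gives the lowest number. No measurement at hand explains these steps.

Still open, on these data alone, is whether the remaining methoxy contributes at all. An unsubstituted phenyl or a 4-aminophenyl at this place would test that.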